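This account rests on a few compounds, and the source may have more. Where it says the series, first, only, none or still open, it means among the compounds named here.

Measured in a functional assay on HT-29 cells (Homo sapiens) for inhibition, read by sulforhodamine B assay, with a stated time of 48 h; a higher number here means a weaker inhibitor of growth, a lower number a stronger inhibitor of growth:
compound 1 `COc1ccc(-c2cc(/C=C/C(=O)c3ccc(N)cc3)[nH]n2)cc1` gives 2750 nM
compound 2 `COc1cc(-c2cc(/C=C/C(=O)c3ccc(N)cc3)[nH]n2)cc(OC)c1OC` gives 1850 nM
compound 3 `COc1ccc(C(=O)/C=C/c2cc(-c3cc(OC)c(OC)c(OC)c3)n[nH]2)cc1OC` gives 1620 nM

Compound 2 stands second highest of these three numbers; its nearest neighbour is compound 3, and the step of a 1.1-fold lower number from compound 2 to compound 3 (0.06 log units; within the scatter) lies within the scatter, as does the gap to compound 1. Compound 4 `COc1ccc(-c2cc(/C=C/C(=O)c3ccc(N)cc3)[nH]n2)cc1OC` differs from compound 2 by hydrogen in place of methoxy on an aromatic carbon. Among the compounds with values here, the only single-place step measured, from compound 2 to compound 3, concerns the aryl group on the carbonyl carbon, not the methoxy pattern, so no measured step bears directly on this change. Compound 1, with one methoxy on that ring, and compound 2, with three, sit within the scatter of each other. Compound 4 is therefore expected to show a 1.2-fold higher number from compound 2 to compound 4 (0.08 log units; within the scatter), and its value in this assay is estimated at 2200 nM (range 1100 nM to 4400 nM).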

Compound 4, concentration for 50% growth inhibition: 2600 nM
For compound 4 the middle estimate is 1.2-fold (0.07 log units) below the measured one; the range from low to high includes it.
By their numbers in this assay, from the lowest: compounds 3, 2, 4 and 1 (each within the scatter of the next).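

In this assay hydrogen in place of methoxy on an aromatic carbon gives a 1.4-fold higher number from compound 2 to compound 4 (0.15 log units; within the scatter) and methoxy in place of hydrogen on an aromatic carbon gives a 1.1-fold lower number from compound 1 to compound 4 (0.02 log units; within the scatter) as single-place steps on this ring. Within the data shown here, these are the first steps that bear on its methoxy pattern, and neither moves the number beyond the scatter. At this position, with either methoxy or hydrogen, the growth read-out stays level.

As far as these compounds go, whether a hydroxy group, a chlorine atom or a longer alkoxy chain on this carbon would move the number stays open. No evidence at hand explains this result.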